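This account rests on a few compounds, and the source may have more. Where it says the series, first, only, none or still open, it means among the compounds named here.

Measured in an ADME assay on HEK293 cells (Homo sapiens) for cytotoxicity, read by ATP content, with a stated time of 6 h; on this read-out higher numbers stand for lower toxicity in this test and lower numbers for higher toxicity in this test:
Compound 1 `CCCCNc1nc(N)nc2ccn(CCCc3ccccc3)c12`: > 24000 nM (a limit)
Compound 2 `Cc1nc(CNc2nc(N)nc3ccn(Cc4ccccn4)c23)cs1`: > 24000 nM (a limit)

Neither compound gives a number in this assay, only a limit of the assay. Compound 2 stands together with compound 1 at the limit of > 24000 nM in this assay, at which 2 of the 2 values shown sit, so its place on the scale is known from one side only.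

The next compound is compound 3 `Cc1cc(CNc2nc(N)nc3ccn(Cc4ccccn4)c23)no1`, which has not yet been measured. It keeps everything in compound 2 except one group. On a saturated chain carbon bound to a nitrogen on an aromatic ring, 5-methyl-1,2-oxazol-3-yl stands in place of 2-methyl-1,3-thiazol-4-yl: 5-methyl-1,2-oxazol-3-yl in place of 2-methyl-1,3-thiazol-4-yl on a saturated chain carbon bound to a nitrogen on an aromatic ring.

Among the compounds with values here, no measured pair shows what such an exchange does in this assay. The expectation therefore rests on compound 2 alone, whose > 24000 nM is a limit. The expected change, a step that the limit leaves unreadable from compound 2 to compound 3, is none beyond the scatter, with neither direction favoured, and another limit is the likeliest report. For compound 3 the estimated value is 30000 nM, with an expected range from 15000 nM to 60000 nM.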

Compound 3, half-maximal cytotoxic concentration: > 24000 nM
Compound 3: only a limit was reported; the forecaster's own chance of this, stated with the estimate: 85%; the middle value lies beyond the limit too.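

Compound 3 gives > 24000 nM in this assay and that value is a limit, not a number. Compound 2 also carries only a limit, so no step can be read from compound 2 to compound 3. The compounds shown leave open whether 5-methyl-1,2-oxazol-3-yl and 2-methyl-1,3-thiazol-4-yl differ at all on this read-out.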